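The compounds below may be only part of what the source reports. "The series", "measured", "known", "first", "only" and "open" are said of these compounds alone.

Compound 2 `O=C(/C(=C\c1ccc(O)c([N+](=O)[O-])c1)SCc1ccc(Br)cc1)c1ccc(C(F)(F)F)cc1`, a ketone bearing a trifluoromethylphenyl group, is the weakest growth inhibitor among the three measured compounds: in a functional assay on DU-145 cells (Homo sapiens) for inhibition, read by trypan blue exclusion, with a stated time of 96 h (a lower number here means a stronger inhibitor of growth, a higher number a weaker inhibitor of growth), compound 2 gives 10000 nM. Compound 1 `Cc1ccc(/C=C(\C(=O)c2ccc(Cl)cc2)S(=O)(=O)Cc2ccc(Cl)cc2)s1` gives 1000 nM in this assay, and compound 3 `O=C(/C(=C\c1ccc([N+](=O)[O-])c(O)c1)SCc1ccc(Br)cc1)c1ccc(C(F)(F)F)cc1` gives 1000 nM. Within the data shown here, the one step measured between close neighbours, a 10-fold lower number from compound 2 to compound 3 (1.00 log units; beyond the scatter), concerns the phenol ring on the double-bonded chain carbon, not the ketone side.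

Compound 4 `O=C(/C(=C\c1ccc(O)c([N+](=O)[O-])c1)SCc1ccc(Br)cc1)c1ccc([N+](=O)[O-])cc1` differs from compound 2 on that ketone side: nitro in place of trifluoromethyl on an aromatic carbon. Among the measured compounds shown here, no measured step touches this position, so the only guide is that compound 2 itself is the starting point and nothing shows whether a change here moves the number at all. The expected step of no change at the digits printed from compound 2 to compound 4 (within the scatter) is therefore small, within the scatter, with wide uncertainty in either direction.

Compound 4 is thus estimated at 10000 nM in this assay, within a range from 2500 nM to 40000 nM.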

Compound 4, concentration for 50% growth inhibition: 10000 nM
Compound 4: the middle estimate sits on the measured number at the digits printed; measured number inside the range.
By their numbers in this assay, from the lowest: compounds 1 and 3 (each within the scatter of the next); then compounds 2 and 4 (each within the scatter of the next).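

In this assay, among these compounds, the exchange of trifluoromethyl for nitro on the ketone side gives no change at the digits printed from compound 2 to compound 4 (within the scatter) and so provides the first measured reading at this place on the aromatic ring, para to a large group. Among the compounds shown here, the change from 4-(trifluoromethyl)phenyl to 4-nitrophenyl leaves the number unmoved, whereas the change on the other ring gives a 10-fold lower number from compound 2 to compound 3 (1.00 log units; beyond the scatter) and thus a step beyond the scatter, so in this small set only that other ring shows a measurable response. Nothing measured here explains why the number holds steady at this place.

On these data alone, whether the same exchange would also leave the number unmoved with the 3-hydroxy-4-nitrophenyl ring of compound 3 remains open. Also open, as far as these compounds go, is whether an amine or a carboxylic acid at this place would shift growth inhibition.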